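The source may report more compounds than this note shows. Statements on the series, on what has been measured and on what is new or still open speak of the compounds shown alone.

Compound 1 `CCS(=O)(=O)Nc1ccc(NC(=O)c2cccc(C(F)(F)F)c2)cc1OC` and compound 2 `CCS(=O)(=O)Nc1ccc(NC(=O)c2cc(C(F)(F)F)cc(C(F)(F)F)c2)cc1OC` share one core, and compound 2 differs from compound 1 by trifluoromethyl in place of hydrogen on an aromatic carbon. In an ADME assay on HEK293 cells (Homo sapiens) for cytotoxicity, read by MTT assay, with a stated time of 48 h (a higher number here means a weaker inhibitor, a lower number a stronger inhibitor), compound 1 reaches only a limit of the assay, > 250000 nM. In this assay compound 2 likewise reaches only a limit, > 250000 nM. The step that the two limits leave unreadable from compound 1 to compound 2 accordingly shows nothing of its size.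

Compound 3 `CS(=O)(=O)Nc1ccc(NC(=O)c2cccc(C(F)(F)F)c2)cc1Cl` stands on a second core; the difference between the two cores is not broken down here. In this assay compound 3 also gives only a limit, > 250000 nM. All three values thus gather at one point, (the limit of > 250000 nM in this assay, at which 3 of the 3 values shown sit).

Compound 4 `CS(=O)(=O)Nc1ccc(NC(=O)c2cc(C(F)(F)F)cc(C(F)(F)F)c2)cc1Cl` has not yet been measured in this assay. It differs from compound 3 by trifluoromethyl in place of hydrogen on an aromatic carbon, the same change that turns compound 1 into compound 2, made at a place described in the same words. The observer therefore expects the step that the limit leaves unreadable from compound 3 to compound 4 to be negligible, an expectation that rests on compound 3 sitting at > 250000 nM and on all three values gathering at the limit of > 250000 nM in this assay, at which 3 of the 3 values shown sit. Compound 4 is expected to stay at the limit as well, with an estimate of 300000 nM and a range expected to run from 150000 nM to 1000000 nM.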

Compound 4, half-maximal inhibitory concentration: 185000 nM
Compound 4: middle estimate off by 1.6-fold (0.21 log units), on the high side; low and high end bracket the measured number.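

In this assay, carrying the trifluoromethyl change onto the core of compound 3 gives an at least 1.3-fold lower number from compound 3 to compound 4 (0.13 log units; that floor lies within the scatter), and compound 4 is the only compound shown that gives a number and not a limit. From the compounds shown here alone, this shows that the change can leave a readable value on this core, but the floor of the step alone does not establish a real drop, and the true size of the step stays unknown. The same change on the core of compound 1 cannot be read, so the two steps cannot be set against each other, and nothing shows whether the change carries over from one core to the other with the same size, because so few values lie clear of one point: the limit of > 250000 nM in this assay, at which 3 of the 4 values shown sit.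

The compounds shown leave open whether another group at this place on the aromatic ring, such as a nitrile, an amine or a carboxylic acid, would also give a number and not a limit. They also leave open how a longer chain on the sulfonyl group, or an amine in that chain, would read in this assay on either core.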